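Trading cyclohexyl for ethyl in compound 4

The source may hold more compounds than are shown below. What is called first, only, known or untested is meant among the compounds shown, and "the series" means these compounds.

Within the data shown here, in an ADME assay on MDBK cells (Bos taurus) for cytotoxicity, read by MTT assay (a higher number here means that more compound is tolerated, a lower number that less compound is tolerated), compound 1 (`OC[C@@H]1[C@@H](O)[C@H](O)[C@@H](O)CN1CCCCCCOC1CCCCC1C1CCCCC1`) gives 200000 nM as the only actual number among the values shown. Compound 2 (`OC[C@@H]1[C@@H](O)[C@H](O)[C@@H](O)CN1CCCCCCOc1ccccc1C(F)(F)F`) reads > 500000 nM and this is a limit of the assay. Compound 3 (`OC[C@@H]1[C@@H](O)[C@H](O)[C@@H](O)CN1CCC#CCCOc1cc(F)ccc1F`) reads > 500000 nM and this too is a limit. Compound 4 (`CCC1CCCCC1OCCCCCCN1C[C@H](O)[C@@H](O)[C@H](O)[C@H]1CO`) keeps the core of compound 1 but carries ethyl in place of cyclohexyl on a saturated ring carbon. Among the measured compounds shown here, no measured step is available to size this change, so in this assay only a modest rise is expected, about the size of the scatter, and a reading at the limit is possible. The expected change is a 1.8-fold higher number from compound 1 to compound 4 (0.24 log units; within the scatter) in this estimate. Compound 4 is estimated at 350000 nM with an expected range from 150000 nM to 800000 nM for now.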

Compound 4, half-maximal cytotoxic concentration: 450000 nM
The estimate for compound 4 lay 1.3-fold (0.11 log units) below the measured number; the measured number falls inside the stated range.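

In this assay, ethyl in place of cyclohexyl on a saturated ring carbon, next to the ring atom that bears a large group, gives a 2.3-fold higher number from compound 1 to compound 4 (0.35 log units; beyond the scatter). Among these compounds, this is the first sized step at this position, and it moves towards more compound being tolerated. Compound 4 still reads as a number, yet little room remains before the reading reaches a limit: the limit of > 500000 nM in this assay, at which 2 of the 4 values shown sit.

On these data alone, with a single step, it stays open whether losing the ring or losing carbon atoms matters here. A cyclopropyl group, a hydroxyl or an amine on this carbon could separate the two.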